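Compound 2 to compound 4: sulfonyl replaced by benzylcarbamoyl

The source may report more compounds than this note shows. Statements on the series, on what has been measured and on what is new or still open speak of the compounds shown alone.

In a functional assay for inhibition, with Homo sapiens as the target (a lower number here means a stronger inhibitor, a higher number a weaker inhibitor), compound 2 `O=C(NC[C@H](NS(=O)(=O)c1cccs1)C(=O)O)c1cc2cc(CCC3CCNCC3)sc2s1` gives 9 nM and compound 3 `O=C(NC[C@H](NS(=O)(=O)c1ccc(Cl)cc1)C(=O)O)c1cc2cc(CCC3CCNCC3)sc2s1` gives 11 nM, two values within the scatter of each other at the low end of the series. Compound 1 `O=C(NC[C@H](NS(=O)(=O)c1cccnc1)C(=O)O)c1cc2cc(CC3CCNCC3)sc2s1` gives 23 nM, a higher number than compound 2 and beyond the scatter.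

Compound 4 `O=C(NCc1ccccc1)N[C@@H](CNC(=O)c1cc2cc(CCC3CCNCC3)sc2s1)C(=O)O` has benzylcarbamoyl in place of (thiophen-2-yl)sulfonyl on an amine nitrogen.

Going by the values given here, one measured step bears on this change: a 1.2-fold higher number from compound 2 to compound 3 (0.09 log units; within the scatter), with 4-chlorophenyl in place of thiophen-2-yl on a sulfonyl sulfur. That step lies within the scatter, but it keeps the sulfonyl, so it covers only the exchange of the aromatic ring. Among the compounds with values here, no measured compound lacks the sulfonyl, and the data therefore give no direct measure of its replacement. A small move towards a higher number in this assay is expected, without a step clearly beyond the scatter. The expected step is a 1.7-fold higher number from compound 2 to compound 4 (0.22 log units; within the scatter). For compound 4 the estimated value is 15 nM, with an expected range of 5 nM to 50 nM.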

Compound 4, half-maximal inhibitory concentration: 76 nM
Beside the measured number, compound 4's estimate is 5.1-fold (0.70 log units) below it; the measured number lies above the stated range.
By their numbers in this assay, from the lowest: compounds 2 and 3 (each within the scatter of the next); then compound 1; then compound 4.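

Replacing (thiophen-2-yl)sulfonyl with benzylcarbamoyl on the amine nitrogen in this assay gives an 8.4-fold higher number from compound 2 to compound 4 (0.93 log units; beyond the scatter), and replacing (4-chlorophenyl)sulfonyl gives a 6.9-fold higher number from compound 3 to compound 4 (0.84 log units; beyond the scatter). Both steps lie beyond the scatter, whereas exchanging the aromatic ring while keeping the sulfonyl gave only a 1.2-fold higher number from compound 2 to compound 3 (0.09 log units; within the scatter), so this position responds more to the change of the whole group than to that ring exchange. No evidence at hand accounts for these steps.

The two steps change the sulfonyl and the aromatic ring together, so the contribution of each remains unresolved. A benzylsulfonyl group on the same nitrogen would keep the sulfonyl with the benzyl ring, while a (thiophen-2-yl)carbamoyl group would keep the thiophene with the urea-type carbonyl, and either could separate the two contributions.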